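The source may report more compounds than this note shows. Statements on the series, on what has been measured and on what is new or still open speak of the compounds shown alone.

Measured in an ADME assay on MDCK cells (Canis lupus familiaris) for cytotoxicity, read by MTT assay, with a stated time of 24 h; a lower number here means that less compound is tolerated, a higher number that more compound is tolerated:

- Compound 1 `COc1ccc(S(=O)(=O)N(CCC#N)Cc2cccs2)cc1`: > 198000 nM (a limit)
- Compound 2 `CC(=O)c1ccc(S(=O)(=O)N(CCC#N)Cc2cccs2)cc1`: > 191000 nM (a limit)
- Compound 3 `O=S(=O)(c1ccc(Br)cc1)N(Cc1cccs1)Cc1cccs1`: 81000 nM

Two of these three entries are limits. Only compound 3 at 81000 nM has an actual number. That makes it the one firm reference point for the next compound.

Compound 4 `O=C(O)CCN(Cc1cccs1)S(=O)(=O)c1ccc(Br)cc1` keeps the bromine-bearing sulfonamide part of compound 3 but changes one arm on the sulfonamide nitrogen. The difference is carboxymethyl in place of thiophen-2-yl on a saturated chain carbon bound to a sulfonamide nitrogen. Put simply, carboxymethyl takes the place of thiophen-2-yl, and the same change can be read as (thiophen-2-yl)methyl to 2-carboxyethyl.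

Among the measured compounds shown here, the only measured step is a step that the two limits leave unreadable from compound 1 to compound 2. It concerns a different change, acetyl in place of methoxy, so it gives no size to borrow. The better guide is the structures themselves. Compound 1 carries only one (thiophen-2-yl)methyl, as compound 4 will. For compound 1 the reading > 198000 nM is a limit. Compound 2 shares that feature, and its > 191000 nM is also a limit.

On that thin basis, a shift towards more compound being tolerated is expected, and the reading may well come back as a limit too. The estimated change is a 2.1-fold higher number from compound 3 to compound 4 (0.32 log units; beyond the scatter). Compound 4 is expected at 170000 nM, with an estimated range from 85000 nM to 260000 nM.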

Compound 4, half-maximal cytotoxic concentration: > 164000 nM
Compound 4: only a limit was reported; the forecaster's own chance of this, stated with the estimate: 65%; the middle value is on the limit's open side.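

In this assay, carboxymethyl in place of thiophen-2-yl on a saturated chain carbon bound to a sulfonamide nitrogen gives an at least 2.0-fold higher number from compound 3 to compound 4 (0.30 log units; that floor lies within the scatter). Compound 4 is reported only as a limit, not as an actual number: the limit of > 164000 nM in this assay, at which 1 of the 4 values shown sits. The other step among these compounds cannot be read, so this is the first with a direction, showing that exchanging the thiophen-2-yl for carboxymethyl at this position brings no drop in the number, although the floor of the step lies within the scatter and does not by itself establish a real rise.

The compounds shown leave open how far the true value of compound 4 lies past its limit, and so how large this step really is. They also cannot separate the loss of the thiophen-2-yl from the arrival of the carboxylic acid, a question that a methyl ester, a primary amide or a plain propyl chain in that same place would help to answer.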